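Thiocarbamate-linked benzamides: methylpiperazine replacing the aryl piperazine

The source may report more compounds than this note shows. Statements on the series, on what has been measured and on what is new or still open speak of the compounds shown alone.

Compound 3 `N#Cc1ccc(N2CCN(C(=S)SCc3ccc(C(=O)Nc4ccccc4N)cc3)CC2)cc1` stands lowest of the three measured: in a functional assay on A-375 cells (Homo sapiens) for antiproliferative activity, read by CCK-8 assay, with a stated time of 72 h, tested at 8 uM (on this read-out lower numbers stand for a weaker effect and higher numbers for a stronger effect at the one concentration tested), compound 3 gives 62.9%, while compound 2 `CC1CCCCN1C(=S)SCc1ccc(C(=O)Nc2ccccc2N)cc1` gives 85.2% and compound 1 `Nc1ccccc1NC(=O)c1ccc(CSC(=S)N2CCc3ccccc32)cc1` gives 85.4%. Compound 4 `CN1CCN(C(=S)SCc2ccc(C(=O)Nc3ccccc3N)cc2)CC1` differs from compound 3 by methyl in place of 4-cyanophenyl on an amine nitrogen in a ring. For the measured compounds named here, the only measured step, a number 0.2 percentage points lower from compound 1 to compound 2 (within the scatter), swaps the whole amine on the thiocarbonyl carbon and does not touch the ring nitrogen changed here, so it bears on compound 4 only loosely. The values of compound 3 against compound 1 and compound 2 suggest the 4-cyanophenyl piperazine sits at the weak end, so a rise is expected but with wide uncertainty. Compound 4 is estimated at 73%, range 55% to 90%, an expected step of a number 10.1 percentage points higher from compound 3 to compound 4 (beyond the scatter).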

Compound 4, a percentage reported as inhibition, at one concentration (the size of the read-out at that concentration, not a potency): 91.6%
The estimate for compound 4 lay 18.6 percentage points below the measured number; measured number above the stated range.
By their numbers in this assay, from the lowest: compound 3; then compounds 2, 1 and 4 (each within the scatter of the next).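

Methyl in place of 4-cyanophenyl on this amine nitrogen gives a number 28.7 percentage points higher from compound 3 to compound 4 (beyond the scatter) in this assay, so the low value of compound 3 goes with the 4-cyanophenyl and not with the piperazine as such. The methylpiperazine also matches the other two amines, with a number 6.4 percentage points higher from compound 2 to compound 4 (within the scatter) and a number 6.2 percentage points higher from compound 1 to compound 4 (within the scatter) as the printed steps. No evidence bearing on the reason for the change is at hand.

Open, as far as these compounds go, is whether the aromatic ring or the nitrile goes with the lower value; an unsubstituted phenyl on this nitrogen would separate the two. Potency also remains open, as only one concentration is shown.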